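A few compounds are considered here, and "the series" means these few. Any claim that something is new, unique, unknown or untested is made for them only; others in the source may bear on it.

Going by the values given here, in an ADME assay on Vero 76 cells (Chlorocebus sabaeus) for cytotoxicity (a higher number here means that more compound is tolerated, a lower number that less compound is tolerated), three compounds have numbers so far. Compound 1 `COc1ncc(-c2cnn(COCCO)c2)c(OC)n1` gives 50000 nM. Compound 2 `COc1nc(N)ncc1-c1cnn(COCCOC(C)=O)c1` gives >= 57000 nM, which is a limit and not a number. Compound 3 `COc1ncc(-c2cnn(COCCOC(C)=O)c2)c(OC)n1` gives >= 53000 nM, which is also a limit. Compound 2 is therefore known only as a limit, and so is one of the other two compounds.

The next compound, compound 4 `COc1nc(N)ncc1-c1cnn(COCCO)c1`, differs from compound 2 in one place: hydrogen in place of acetyl on an oxygen on a saturated carbon. Hydrogen replaces acetyl on an oxygen on a saturated carbon, so 2-acetoxyethyl becomes 2-hydroxyethyl.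

The same exchange has been measured in the opposite direction, on the core of compound 1, as an at least 1.0-fold higher number from compound 1 to compound 3 (0.02 log units; that floor lies within the scatter). That step adds acetyl and stays within the scatter. The other measured step, a step that the two limits leave unreadable from compound 2 to compound 3, is methoxy in place of amino on an aromatic carbon, and it cannot be read for size. Only the first step therefore guides the expectation, and it points to no shift beyond the scatter in this assay.

The expected step is an at least 1.1-fold lower number from compound 2 to compound 4 (0.05 log units; that floor lies within the scatter). For compound 4 the estimate is 50000 nM, with an expected range of 25000 nM to 100000 nM.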

Compound 4, half-maximal cytotoxic concentration: >= 1200 nM
Compound 4 ended at the assay's limit; the forecaster's own chance of this, stated with the estimate: 55%; the middle value lies beyond the limit too.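

In this assay compound 4 gives >= 1200 nM, which is a limit and not a number. Its steps from compound 2 and from compound 1 therefore cannot be read for size. The compounds shown leave open whether 2-hydroxyethyl in place of 2-acetoxyethyl, or amino in place of methoxy, changes how much compound the cells tolerate.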